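Furan-2-yl for pyridin-3-yl on the shared core

A few compounds are considered here, and "the series" means these few. Any claim that something is new, unique, unknown or untested is made for them only; others in the source may bear on it.

Compound 1 `Oc1ccc(-c2cc(-c3ccc(Cl)cc3)nc(-c3cccnc3)c2)cc1` and compound 3 `Oc1cccc(-c2cc(-c3ccc(Cl)cc3)nc(-c3cccnc3)c2)c1` share one core and differ only in the position of the hydroxyl on the phenyl ring. In a functional assay on DU-145 cells (Homo sapiens) for cytotoxicity, read by CCK-8 assay and cell counting, with a stated time of 2 days (on this read-out higher numbers stand for weaker inhibition and lower numbers for stronger inhibition), compound 1 gives 22800 nM, and compound 3 gives 26800 nM. Among the measured compounds shown here, the step of a 1.2-fold higher number from compound 1 to compound 3 (0.07 log units; within the scatter) is the only measured step in the set, and it falls within the scatter, so the two numbers cannot be told apart. Compound 2 `Oc1cccc(-c2cc(-c3cccnc3)nc(-c3ccccc3Cl)c2)c1` has no number in this assay; its entry reads "not determined" (no result reported). Compound 3 thus stands with compound 1 as one of two indistinguishable values, with nothing else to compare against.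

Compound 4 `Oc1cccc(-c2cc(-c3ccc(Cl)cc3)nc(-c3ccco3)c2)c1` is compound 3 with furan-2-yl in place of pyridin-3-yl on an aromatic carbon. For the measured compounds named here, no measured pair in the set exchanges the group next to the ring nitrogen, so no step bears directly on this change; the one step that exists concerns the hydroxyphenyl only and stayed within the scatter. With no evidence of a direction, the expectation for this assay is a step of no more than the scatter either way, that is a 1.0-fold higher number from compound 3 to compound 4 (0.00 log units; within the scatter). Compound 4 is therefore estimated at 27000 nM, with a range from 9000 nM to 80000 nM.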

Compound 4, half-maximal inhibitory concentration: 11400 nM
The estimate for compound 4 lay 2.4-fold (0.37 log units) above the measured number; low and high end bracket the measured number.
By their numbers in this assay, from the lowest: compounds 4, 1 and 3 (each within the scatter of the next, the first and the last beyond it).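

Among the compounds shown here, the position carrying the pyridin-3-yl group, next to the ring nitrogen, is the first place where a single exchange moves the number in this assay beyond the scatter: furan-2-yl in place of pyridin-3-yl gives a 2.4-fold lower number from compound 3 to compound 4 (0.37 log units; beyond the scatter) and thus stronger inhibition, though the step is modest. For the compounds shown here, the only earlier step, a 1.2-fold higher number from compound 1 to compound 3 (0.07 log units; within the scatter) on moving the hydroxyl, stayed within the scatter, so this position responds to change in a way the hydroxyphenyl exchange did not show. The data shown include nothing that bears on what lies behind this step.

The exchange replaces a six-membered ring holding a nitrogen with a five-membered ring holding an oxygen, so one pair cannot separate ring size from the identity of the hetero atom; thiophen-2-yl and phenyl at the same position would be the informative neighbours, as would an amine or a carboxylic acid on the ring. Also open, going by these compounds, is whether the step holds with a 4-hydroxyphenyl group in place of the 3-hydroxyphenyl group, since it rests on this single pair.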